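The source may hold more compounds than are shown below. What is called first, only, known or untested is meant among the compounds shown, and "the series" means these compounds.

Compound 1 `C[C@H]1CC[C@@H]2[C@@H](OC(=O)[C@]23CC(c2c(Cl)cccc2Cl)=NO3)[C@]2(C)C(=O)C=C[C@@]12O`: 38000 nM
Compound 2 `C[C@H]1CC[C@@H]2[C@@H](OC(=O)[C@]23CC(c2ccc(N(C)C)cc2)=NO3)[C@]2(C)C(=O)C=C[C@@]12O`: 4500 nM
Compound 3 `Cc1ccccc1C1=NO[C@]2(C1)C(=O)O[C@@H]1[C@H]2CC[C@H](C)[C@]2(O)C=CC(=O)[C@@]12C`: 12000 nM

These three compounds share one core and were tested in a functional assay on DU-145 cells (Homo sapiens) for cytotoxicity, read by sulforhodamine B assay, with a stated time of 48 h; on this read-out lower numbers stand for stronger inhibition and higher numbers for weaker inhibition. They differ only in the substituted phenyl group on a carbon with a double bond to nitrogen. Compound 3 holds the middle place of the three numbers. Its neighbours on either side are set by a 2.7-fold higher number from compound 2 to compound 3 (0.43 log units; beyond the scatter) and a 3.2-fold lower number from compound 1 to compound 3 (0.50 log units; beyond the scatter), and the whole spread is an 8.4-fold lower number from compound 1 to compound 2 (0.93 log units; beyond the scatter).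

The next compound to be measured is compound 4 `Cc1ccc(C2=NO[C@]3(C2)C(=O)O[C@@H]2[C@H]3CC[C@H](C)[C@]3(O)C=CC(=O)[C@@]23C)cc1`. It has the same atoms as compound 3, joined differently: 4-methylphenyl in place of 2-methylphenyl on a carbon with a double bond to nitrogen. The methyl group stays, but 4-methylphenyl stands in place of 2-methylphenyl.

Within the data shown here, no measured step makes this exact change, so the evidence is indirect. Among the measured compounds shown here, compound 2, with its 4-(dimethylamino)phenyl, gives 4500 nM, the lowest number so far. This hints that a group named at the 4 position may suit these compounds, but compound 2 carries a different group and is only a loose guide. All three measured steps are modest, so a large jump seems unlikely. The expected step is a 1.5-fold lower number from compound 3 to compound 4 (0.18 log units; within the scatter), a small move towards lower numbers that may not clear the usual scatter. The estimate for compound 4 is 8000 nM, with an expected range of 3000 nM to 20000 nM.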

Compound 4, half-maximal inhibitory concentration: 14000 nM
The estimate for compound 4 lay 1.8-fold (0.24 log units) below the measured number, within the range that was stated.
By their numbers in this assay, from the lowest: compound 2; then compounds 3 and 4 (each within the scatter of the next); then compound 1.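

Replacing 2-methylphenyl with 4-methylphenyl on the carbon with a double bond to nitrogen gives a 1.2-fold higher number from compound 3 to compound 4 (0.07 log units; within the scatter) in this assay, so the two arrangements of the methyl group on the phenyl ring cannot be told apart here. The hint from compound 2 therefore does not extend to every group at the 4 position: methyl in place of dimethylamino gives a 3.1-fold higher number from compound 2 to compound 4 (0.49 log units; beyond the scatter) and leaves the number well clear of the scatter, so the lower number of compound 2 goes with dimethylamino itself and not simply with having a group at that position. The step of a 2.7-fold lower number from compound 1 to compound 4 (0.43 log units; beyond the scatter) shows that 4-methylphenyl, like 2-methylphenyl, sits on the lower side of 2,6-dichlorophenyl, which means a single methyl group at either position gives a lower number than compound 1 does.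

The compounds shown leave open whether a 4-aminophenyl group, with a plain amine, or a phenyl ring bearing a carboxylic acid at the 4 position would match compound 2 or fall back towards compound 4. Nothing available here explains why these numbers differ.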